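Series notes: aryl-substituted benzoxazole anilines, step to compound 3

The source may report more compounds than this note shows. Statements on the series, on what has been measured and on what is new or still open speak of the compounds shown alone.

Of the compounds shown here, two have numbers so far. Compound 1 `COc1cc(Nc2nc3cccc(-c4c(F)cccc4OC)c3o2)cc(OC)c1` gives 210 nM in an assay on isolated protein for inhibition of ribosomal protein S6 kinase alpha-2 (Homo sapiens), with a stated time of 150 min; on this read-out higher numbers stand for weaker inhibition and lower numbers for stronger inhibition. Compound 2 `COc1cc(Nc2nc3cccc(-c4ccccc4OC(F)(F)F)c3o2)cc(OC)c1OC` gives 4000 nM in this assay, the higher of the two numbers; the gap to compound 1 lies beyond the scatter, and it is the weaker inhibitor of the pair. The two compounds differ in more than one place, so no single step can be read from them.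

Compound 3 `COc1cc(Nc2nc3cccc(-c4ccccc4-c4cn[nH]c4)c3o2)cc(OC)c1OC` is not yet measured. It differs from compound 2 by 1H-pyrazol-4-yl in place of trifluoromethoxy on an aromatic carbon, ortho to a large group. Going by the values given here, no measured pair shows this change, so the size of the step in this assay cannot be drawn from the data; a step toward a lower number is expected, but with a wide spread that also allows no change beyond the scatter.

Compound 3 is estimated at 1500 nM in this assay, with a range from 300 nM to 6000 nM; the expected step is a 2.7-fold lower number from compound 2 to compound 3 (0.43 log units; beyond the scatter).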

Compound 3, half-maximal inhibitory concentration: 9300 nM
For compound 3 the middle estimate is 6.2-fold (0.79 log units) below the measured one; measured number outside the range, above it.
By their numbers in this assay, from the lowest: compound 1; then compound 2; then compound 3.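

In this assay, going by these compounds alone, 1H-pyrazol-4-yl in place of trifluoromethoxy on an aromatic carbon, ortho to a large group, gives a 2.3-fold higher number from compound 2 to compound 3 (0.37 log units; beyond the scatter), a modest change and the first single change that can be read. With the heavy-atom count unchanged, this five-membered aromatic ring and its hydrogen-bond donor do not bring a lower number at this position, so the two compounds show that the number responds to the group placed here, though only by this modest step. Nothing in hand bears on what lies behind the step.

Within the data shown here, compound 1 differs from compound 2 and compound 3 in more than one place, so no step to it can be read, and how its fluorine and methoxy groups and its aniline ring each contribute stays open. Also open, from the compounds shown here alone, is whether a plain phenyl ring at the same place, which has a ring but no hydrogen-bond donor, or an amine, which has a donor but no ring, would give a number nearer that of compound 2 or that of compound 3, a comparison that would separate the ring from the donor.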